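The source may hold more compounds than are shown below. What is called first, only, known or untested is meant among the compounds shown, and "the series" means these compounds.

Compound 3 `Cc1ccc(C(=O)N2N=C(c3cc4ccccc4oc3=O)CC2c2ccccc2)cc1` gives 31300 nM in a functional assay on MGC-803 cells (Homo sapiens) for cytotoxicity, read by MTT assay, with a stated time of 48 h; a lower number here means a stronger inhibitor, a higher number a weaker inhibitor. On the numbers shown it carries the highest value of the three measured compounds: compound 2 `COc1ccccc1C1CC(C)=NN1C(=O)CN1CCC(OC)CC1` gives 9550 nM and compound 1 `CC(=O)Oc1ccccc1C1CC(C)=NN1C(=O)CN1CCC(O)CC1` gives 3510 nM, both lower than compound 3 by more than the scatter. For the measured compounds named here, neither compound 1 nor compound 2 differs from compound 3 in a single place, so no isolated step between measured compounds can be read from them.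

Compound 4 `CCN(CC)C1CCN(CC(=O)N2N=C(c3cc4ccccc4oc3=O)CC2c2ccccc2)CC1` is not yet measured. It differs from compound 3 by a single change: (4-(diethylamino)piperidin-1-yl)methyl in place of 4-methylphenyl on a carbonyl carbon. Because compound 1 gives 3510 nM and compound 2 gives 9550 nM, both well under the number of compound 3, a move toward a lower number in this assay is expected, though the different substituents on the shared core of those compounds keep the expectation loose. The step from compound 3 to compound 4 is estimated as a 3.5-fold lower number from compound 3 to compound 4 (0.54 log units; beyond the scatter), beyond the scatter in the direction of a stronger inhibitor. Compound 4 is therefore expected to give about 9000 nM, with a range from 2500 nM to 32000 nM.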

Compound 4, half-maximal inhibitory concentration: 32400 nM
Beside the measured number, compound 4's estimate is 3.6-fold (0.56 log units) below it, outside the stated range (above it).
By their numbers in this assay, from the lowest: compound 1; then compound 2; then compounds 3 and 4 (each within the scatter of the next).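

In this assay, (4-(diethylamino)piperidin-1-yl)methyl in place of 4-methylphenyl on the carbonyl carbon gives a 1.0-fold higher number from compound 3 to compound 4 (0.02 log units; within the scatter). For the compounds shown here, this is the first single-place comparison in the set, and it shows that this position takes a larger non-aromatic group with two nitrogens, in place of an all-carbon aromatic ring, with no change in the read-out beyond the scatter. Compound 1 and compound 2 differ from both compounds in more than one place, so no steps to them can be read, and nothing measured here accounts for the two groups reading alike.

The compounds shown leave open whether a morpholine or a carboxylic acid on this carbonyl carbon would move the number. They also leave open whether the same exchange would read alike with other groups on the shared core.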